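Chloro to Methyl on the Aryl Ring of Pyridinylpiperazine Oximes

The source may report more compounds than this note shows. Statements on the series, on what has been measured and on what is new or still open speak of the compounds shown alone.

Measured compounds:
compound 1, `O/N=C(\CCN1CCN(c2ccccn2)CC1)c1cccc(Cl)c1`, 11.9 nM
compound 2, `Cc1cccc(/C(CCN2CCN(c3ccccn3)CC2)=N/O)c1`, 2.3 nM
compound 3, `CO/N=C(\CCN1CCN(c2ccccn2)CC1)c1ccccc1Cl`, 42.3 nM

Three compounds were tested in a functional assay on HEK293 cells with D(4) dopamine receptor (Homo sapiens) as the target, read by FLIPR; on this read-out lower numbers stand for an effect already at smaller amounts and higher numbers for an effect only at larger amounts of compound. Compound 1 gives 11.9 nM, compound 2 gives 2.3 nM, and compound 3 gives 42.3 nM. Compound 3 stands highest of the three; its nearest neighbour is compound 1, and compound 2 lies furthest from it.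

Compound 1 and compound 2 differ in one place: methyl in place of chloro on an aromatic carbon. This step gave a 5.2-fold lower number from compound 1 to compound 2 (0.71 log units; beyond the scatter).

Compound 4, `CO/N=C(\CCN1CCN(c2ccccn2)CC1)c1ccccc1C`, has not been measured in this assay. It differs from compound 3 by methyl in place of chloro on an aromatic carbon. The difference between the core of compound 3 and the core of compound 1 is not broken down here. Among the compounds with values here, the change from compound 3 to compound 4 is the same kind of change as the one from compound 1 to compound 2, but not the same: in the first pair the group sits meta to a large group, while in the second pair it sits ortho to a large group.

Given that the earlier step lowered the number in this assay, compound 4 is expected to fall below compound 3, with a step estimated at a 3.3-fold lower number from compound 3 to compound 4 (0.51 log units; beyond the scatter), tempered because the place around the group differs and compound 3 starts from 42.3 nM. Compound 4 is therefore expected to give 13 nM, between 4 nM and 40 nM.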

Compound 4, half-maximal effective concentration: 74 nM
Compound 4: the middle estimate sits 5.7-fold (0.76 log units) below what was measured, and the stated range ends below it.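

In this assay, methyl in place of chloro on an aromatic carbon did not give the same result on the two cores: the same change on two cores in this assay, a 5.2-fold lower number (0.71 log units; beyond the scatter) from compound 1 to compound 2 and a 1.7-fold higher number (0.24 log units; within the scatter) from compound 3 to compound 4, 9.1-fold (0.96 log units) apart, beyond the scatter of two such steps. On the core of compound 3, the new step (a 1.7-fold higher number from compound 3 to compound 4 (0.24 log units; within the scatter)) stays within the scatter, so the 2-chlorophenyl and 2-methylphenyl compounds cannot be told apart here, and the lower number seen on the core of compound 1 does not carry over to this pair. This does not show why the two steps differ, since the pairs differ both in their cores and in the place of the changed group, and these two differences are not separated by the four compounds; two pairs also establish no rule for the wider series.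

The compounds shown leave open whether the step depends on the core or on the place of the group, a question that a matched pair with the same core and the group in the other place could settle. They also leave open how a fluoro or methoxy group at the same aromatic carbon, or a longer chain in place of the methyl on the oxime oxygen, would read on this core.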